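The compounds below may be only part of what the source reports. "The series", "measured", "known", "first", "only" and "open" are said of these compounds alone.

Measured compounds:
compound 1, `Nc1nc(-c2ccccc2)c(C(=O)c2cnc3ccccn23)s1`, 40%
compound 2, `Cc1ccn2c(C(=O)c3sc(N)nc3-c3ccccc3)cnc2c1`, 26%
compound 3, `Cc1nc(N)sc1C(=O)c1cnc2ccccn12`, 53%

In a functional assay on the whole organism (strain Sprague-Dawley) for inhibition, with Rattus norvegicus as the target, read by paw edema, with stated times of 1 h and 3 h, at a dose of 50 mg/kg by the oral route (on this read-out lower numbers stand for less inhibition and higher numbers for more inhibition at the one dose given (going by the name of the read-out)), compound 1 gives 40%, compound 2 gives 26%, and compound 3 gives 53%. Compound 3 stands highest of the three, and its steps to compound 1 and to compound 2 are both beyond the scatter. Compound 2 differs from compound 1 by a single change, (methyl in place of hydrogen on an aromatic carbon), which gives a number 14 percentage points lower from compound 1 to compound 2 (beyond the scatter). Compound 3 differs from compound 1 in the core, (methyl in place of phenyl on an aromatic carbon), which gives a number 13 percentage points higher from compound 1 to compound 3 (beyond the scatter).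

Compound 4, `Cc1ccn2c(C(=O)c3sc(N)nc3C)cnc2c1`, has not yet been measured in this assay. It carries the core of compound 3 and differs from it by methyl in place of hydrogen on an aromatic carbon. The place is described in the same words as for the change from compound 1 to compound 2, so this is the same change applied to the other core. Among the measured compounds shown here, only one measured instance of it exists, and whether its effect carries over to the core of compound 3 cannot be checked from the data at hand. The step from compound 3 to compound 4 in this assay is expected to be a number 13 percentage points lower from compound 3 to compound 4 (beyond the scatter), resting on the change from compound 1 to compound 2 having given a number 14 percentage points lower from compound 1 to compound 2 (beyond the scatter). Compound 4 is accordingly estimated at 40% in this assay. The expected range for compound 4 runs from 25% to 55%, the width reflecting that a single precedent supports the transfer.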

Compound 4, a percentage reported as inhibition, in the whole organism at one dose (the size of the read-out at that dose, not a potency): 66%
Estimate against measurement, compound 4: 26 percentage points below, outside the stated range (above it).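

In this assay, methyl in place of hydrogen on an aromatic carbon does not carry over from the core of compound 1 to the core of compound 3, since a number 13 percentage points higher from compound 3 to compound 4 (beyond the scatter) runs opposite to the earlier step: the same change on two cores in this assay, a number 14 percentage points lower (beyond the scatter) from compound 1 to compound 2 and a number 13 percentage points higher (beyond the scatter) from compound 3 to compound 4, 27 percentage points apart, beyond the scatter of two such steps

Methyl in place of phenyl on an aromatic carbon keeps its direction but not its size, with a number 40 percentage points higher from compound 2 to compound 4 (beyond the scatter) against the smaller earlier step: the same change on two cores in this assay, a number 13 percentage points higher (beyond the scatter) from compound 1 to compound 3 and a number 40 percentage points higher (beyond the scatter) from compound 2 to compound 4, 27 percentage points apart, beyond the scatter of two such steps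

These two comparisons come from the same four compounds and so record one non-additive result rather than two independent ones; they show that neither change can be assigned a fixed contribution in this series, but not why the two changes interact, nor whether a similar reversal would appear with other groups or at another dose.

On these data alone, whether the higher number of compound 4 is particular to methyl remains open: ethyl or methoxy at the same place on the six-membered aromatic ring could follow either direction. As far as these compounds go, it is equally open how a longer chain in place of the methyl that replaces phenyl would behave, and whether such a compound would track compound 4 or compound 2.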